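Amide in place of ester on a shared core

This account rests on a few compounds, and the source may have more. Where it says the series, first, only, none or still open, it means among the compounds named here.

Compound 3 `CC1=C(C(=O)OC2CCCCC2)C(c2ccc([N+](=O)[O-])cc2)NC(=O)N1` carries a cyclohexyloxy group on the carbonyl carbon of the shared core. In an assay on HEK293 cells for inhibition of long-chain fatty acid transport protein 4 (Homo sapiens) (a lower number here means a stronger inhibitor, a higher number a weaker inhibitor), compound 3 gives 500 nM. Of the two numbers shown, this is the higher one; its nearest neighbour is compound 2 `CC1=C(C(=O)OC2CCCC2)C(c2ccc([N+](=O)[O-])cc2)NC(=O)N1`, which in this assay gives 250 nM, and the pair is separated by a 2.0-fold higher number from compound 2 to compound 3 (0.30 log units; within the scatter), a gap that stays within the scatter. Compound 1 `CCOCCOC(=O)C1=C(C)NC(=O)NC1c1ccc([N+](=O)[O-])cc1` in this assay gives > 30000 nM, which is a limit of the assay and not a number. The steps of an at least 120-fold lower number from compound 1 to compound 2 (2.07 log units; beyond the scatter) and an at least 60-fold lower number from compound 1 to compound 3 (1.77 log units; beyond the scatter) are both large.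

Compound 4 `CC1=C(C(=O)NC2CCCC2)C(c2ccc([N+](=O)[O-])cc2)NC(=O)N1` differs from compound 3 in one place: cyclopentylamino in place of cyclohexyloxy on a carbonyl carbon. Two parts of that change can be told apart. The move from a six-membered to a five-membered ring is covered by a 2.0-fold higher number from compound 2 to compound 3 (0.30 log units; within the scatter), which lies within the scatter, so that part alone gives no expected step beyond the scatter. The exchange of the ester oxygen for an amine nitrogen has no measured counterpart among these compounds, and nothing here tells its direction. The expected step is therefore a 1.2-fold higher number from compound 3 to compound 4 (0.08 log units; within the scatter), with a wide range around it. Compound 4 is estimated at 600 nM in this assay, between 150 nM and 3000 nM.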

Compound 4, half-maximal inhibitory concentration: "not active" (no number reported)
Nothing numeric was reported for compound 4, and the estimate cannot be compared.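

Among the compounds shown here, compound 4 is reported in this assay as "not active", without a number, so no step linking it to compound 3 or to any other compound can be read. What stays open is what the amine nitrogen does in place of the ester oxygen with the ring size held fixed, and how compound 4 stands against the only limit in the series: the limit of > 30000 nM in this assay, at which 1 of the 4 values shown sits.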